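Replacing the branched amide chain of compound 3 with a hydroxy group

The source may hold more compounds than are shown below. What is called first, only, known or untested is meant among the compounds shown, and "the series" means these compounds.

Measured so far in an assay on cell membranes for binding affinity to 2-oxoglutarate receptor 1 (Rattus norvegicus), read by radioligand binding; a lower number here means a stronger inhibitor, a higher number a weaker inhibitor:
- compound 1, `CCCCNC(=O)[C@H]1OC(n2cnc3c(N)ncnc32)[C@H](O)[C@@H]1O`, gives 17 nM
- compound 2, `CCCCCCCCCNC(=O)[C@H]1OC(n2cnc3c(N)ncnc32)[C@H](O)[C@@H]1O`, gives 31 nM
- compound 3, `CCC(C)NC(=O)[C@H]1OC(n2cnc3c(N)ncnc32)[C@H](O)[C@@H]1O`, gives 198 nM

All three share one core and differ only in the group carried on the amide-type nitrogen. Compound 3 stands highest of the three numbers in this assay: the step of a 12-fold higher number from compound 1 to compound 3 (1.07 log units; beyond the scatter) is large and the step of a 6.4-fold higher number from compound 2 to compound 3 (0.81 log units; beyond the scatter) is modest, both beyond the scatter, whereas the step of a 1.8-fold higher number from compound 1 to compound 2 (0.26 log units; within the scatter) stays within it. So the two straight chains give similar numbers, and the branched sec-butyl of compound 3 gives a clearly higher one.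

Compound 4, `Nc1ncnc2c1ncn2C1O[C@H](C(=O)NO)[C@@H](O)[C@H]1O`, takes this one step further: hydroxy in place of sec-butyl on an amide-type nitrogen. Among the measured compounds shown here, none of the measured steps covers this kind of change; they only compare one carbon chain with another, and here the chain is removed altogether and a hydroxy enters in its place. For the measured compounds named here, with no step to lean on, the expectation for compound 4 is uncertain and rests mainly on the observation that every measured compound carries a carbon chain on that nitrogen. For compound 4 the number is expected to rise, as a 3.0-fold higher number from compound 3 to compound 4 (0.48 log units; beyond the scatter), and its estimated value is 600 nM, between 60 nM and 6000 nM.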

Compound 4, inhibition constant: 41 nM
For compound 4 the middle estimate is 15-fold (1.17 log units) above the measured one, and the stated range ends above it.
By their numbers in this assay, from the lowest: compounds 1, 2 and 4 (each within the scatter of the next, the first and the last beyond it); then compound 3.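

On the amide-type nitrogen in this assay, a carbon chain turns out not to be needed for a low number: hydroxy in place of sec-butyl gives a 4.8-fold lower number from compound 3 to compound 4 (0.68 log units; beyond the scatter). Set against the straight chains, hydroxy in place of nonyl gives a 1.3-fold higher number from compound 2 to compound 4 (0.12 log units; within the scatter), so no order can be drawn for that pair, while hydroxy in place of butyl gives a 2.4-fold higher number from compound 1 to compound 4 (0.38 log units; beyond the scatter), a modest step that leaves the butyl compound with the lower number. Nothing available explains how hydroxy compares with these chains.

Still open, going by these compounds, is whether this result is particular to hydroxy or would also hold for a methoxy or an amino group on the same nitrogen. The compounds shown also leave open how a carboxylic acid would compare with the hydroxycarbamoyl group as a whole.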